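The source may hold more compounds than are shown below. What is called first, only, known or untested is meant among the compounds shown, and "the series" means these compounds.

Compound 1 `[N-]=[N+]=Nc1nccc2c1ncn2[C@H]1C[C@H](O)[C@@H](CO)O1` gives 13% in a functional assay on EL4 cells (Mus musculus) for inhibition, tested at 100 uM; on this read-out higher numbers stand for more inhibition at the one concentration tested (going by the name of the read-out) and lower numbers for less inhibition.
Compound 2 `OC[C@H]1O[C@@H](n2cnc3cnccc32)C[C@@H]1O` gives < 5% in this assay, which is a limit of the assay and not a number.
Compound 3 `CSc1nccc2c1ncn2[C@H]1C[C@H](O)[C@@H](CO)O1` gives < 5% in this assay, again a limit rather than a number.

Compound 3 thus sits at the floor of what this assay can report, a position it shares with one other compound: the limit of < 5% in this assay, at which 2 of the 3 values shown sit. Only the azido compound rises clearly above that floor. The move to compound 4 `OC[C@H]1O[C@@H](n2cnc3c(S)nccc32)C[C@@H]1O` puts (hydrogen in place of methyl on a sulfur); read one bond further out, the same difference goes from methylsulfanyl to sulfanyl. Going by the values given here, two measured steps touch this part of the molecule. From the azido compound, a number at least 8 percentage points lower from compound 1 to compound 3 (that floor lies within the scatter). Between the two compounds at the floor, a step that the two limits leave unreadable from compound 2 to compound 3, so nothing measured shows how a change at this sulfur-bearing position moves the read-out in either direction. With compound 3 already at a limit and no readable step to lean on, the expectation is that removing the methyl from the sulfur produces no step beyond the scatter, and compound 4 is expected to stay near the floor. The expected step is a step that the limit leaves unreadable from compound 3 to compound 4. Compound 4 is therefore estimated at 4%, between 0% and 12%, most likely reported only as a limit.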

Compound 4, a percentage reported as inhibition, at one concentration (the size of the read-out at that concentration, not a potency): < 5%
Compound 4 ended at the assay's limit; the forecaster's own chance of this, stated with the estimate: 60%; the middle value does not contradict the limit.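

The steps among compound 2, compound 3 and compound 4 cannot be read, so taking the methyl off the sulfur has no measurable size here, and the new result only adds a third compound to the floor: the limit of < 5% in this assay, at which 3 of the 4 values shown sit.

Going by these compounds alone, the one readable new step runs from azido to sulfanyl, a number at least 8 percentage points lower from compound 1 to compound 4 (that floor lies within the scatter), and it has the same form as the earlier steps from azido to hydrogen and to methylsulfanyl. Hydrogen, methylsulfanyl and sulfanyl now all give the same limit at this position, and compound 1, with azido, is the one exception, as the only compound of the four to carry a number rather than a limit.

On these data alone, it remains open whether any other group at this position, such as an amine or a longer chain on the sulfur like ethylsulfanyl, would give a number in this assay. Also open, as far as these compounds go, is how far compound 2, compound 3 and compound 4 lie from one another under the limit they share.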